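From 2-Fluorophenyl to 3-Fluorophenyl on a Shared Core

The compounds below may be only part of what the source reports. "The series", "measured", "known", "first", "only" and "open" are said of these compounds alone.

In a functional assay on MCF7 cells (Homo sapiens) for antiproliferative activity, read by MTT assay, with a stated time of 48 h (on this read-out lower numbers stand for stronger inhibition and higher numbers for weaker inhibition), compound 1 `CC(=O)N1N=C(c2ccc3ccccc3c2)OC1c1cccc(Br)c1` gives 2.34 ug/mL, compound 2 `CC(=O)N1N=C(c2ccc3ccccc3c2)OC1c1ccccc1Cl` gives 2.36 ug/mL and compound 3 `CC(=O)N1N=C(c2ccc3ccccc3c2)OC1c1ccccc1F` gives 3.44 ug/mL. These three values lie within the usual scatter of one another, so compound 3 stands level with the other two.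

Compound 4 `CC(=O)N1N=C(c2ccc3ccccc3c2)OC1c1cccc(F)c1` has the same atoms as compound 3, joined differently, with 3-fluorophenyl in place of 2-fluorophenyl on a saturated ring carbon. This exact move has not been measured, so only neighbouring changes can guide the expectation. Putting 2-chlorophenyl in place of 3-bromophenyl gave a 1.0-fold higher number from compound 1 to compound 2 (0.00 log units; within the scatter). Putting 2-fluorophenyl in place of 3-bromophenyl gave a 1.5-fold higher number from compound 1 to compound 3 (0.17 log units; within the scatter), and fluoro in place of chloro gave a 1.5-fold higher number from compound 2 to compound 3 (0.16 log units; within the scatter). None of these changes moved the number beyond the scatter, so no real shift is expected in this assay here. The estimated change is a 1.2-fold lower number from compound 3 to compound 4 (0.07 log units; within the scatter). Compound 4 is expected at 2.9 ug/mL, with an estimated range of 1.5 ug/mL to 5.4 ug/mL.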

Compound 4, half-maximal inhibitory concentration: 1.98 ug/mL
Beside the measured number, compound 4's estimate is 1.5-fold (0.17 log units) above it; low and high end bracket the measured number.
By their numbers in this assay, from the lowest: compounds 4, 1, 2 and 3 (each within the scatter of the next).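

In this assay the direct swap of 2-fluorophenyl for 3-fluorophenyl on the saturated ring carbon gives a 1.7-fold lower number from compound 3 to compound 4 (0.24 log units; within the scatter) and so shows that moving the fluoro group around this phenyl ring leaves the number within the scatter. Fluoro in place of bromo on an aromatic carbon gives a 1.2-fold lower number from compound 1 to compound 4 (0.07 log units; within the scatter) and 3-fluorophenyl in place of 2-chlorophenyl gives a 1.2-fold lower number from compound 2 to compound 4 (0.08 log units; within the scatter) in the same assay, so neither the choice of halogen nor its place on the ring has yet moved the number beyond the scatter in these four compounds. No measurement at hand explains these small differences.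

The compounds shown leave open whether an amine or a methoxy group on this phenyl ring would shift the number beyond the scatter. They also leave open what a longer chain in place of the acetyl group would do.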